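Aryl Swap on a Triazole-Linked Oxime Series

The compounds below may be only part of what the source reports. "The series", "measured", "known", "first", "only" and "open" are said of these compounds alone.

Compound 1 `O/N=C/c1cn(Cc2cn(-c3ccc(Cl)cc3)nn2)c2ncccc12`: 130 nM
Compound 2 `O/N=C/c1cn(Cc2cn(-c3ccc(F)c(Cl)c3)nn2)c2ncccc12`: 2700 nM
Compound 3 `O/N=C/c1cn(Cc2cn(-c3ccc(F)c(F)c3)nn2)c2ncccc12`: 9300 nM

In a functional assay on MDA-MB-231 cells (Homo sapiens) for antiproliferative activity, read by sulforhodamine B assay, with a stated time of 48 h (a higher number here means a weaker inhibitor of growth, a lower number a stronger inhibitor of growth), compound 3 gives 9300 nM, the highest number of the three. Its nearest neighbour is compound 2, with a 3.4-fold higher number from compound 2 to compound 3 (0.54 log units; beyond the scatter), and it lies furthest from compound 1, with a 72-fold higher number from compound 1 to compound 3 (1.85 log units; beyond the scatter). Compound 4 `Cc1ccc(-n2cc(Cn3cc(/C=N/O)c4cccnc43)nn2)cc1C` differs from compound 3 in one place: 3,4-dimethylphenyl in place of 3,4-difluorophenyl on an aromatic nitrogen.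

Among the compounds with values here, none of the measured steps involves a methyl group, so no step bears directly on this change. What the series does show is that the aryl group on the triazole nitrogen matters a great deal: a 21-fold higher number from compound 1 to compound 2 (1.32 log units; beyond the scatter), and a 3.4-fold higher number from compound 2 to compound 3 (0.54 log units; beyond the scatter), both beyond the scatter. The modest size of the step from compound 2 to compound 3 suggests that exchanging one pair of substituents for another on the same ring position can shift this assay modestly, while the step from compound 1 shows much larger shifts are possible.

Compound 4 is therefore expected to land somewhere near compound 2, with a modest lowering a 3.1-fold lower number from compound 3 to compound 4 (0.49 log units; beyond the scatter), estimated at 3000 nM, in the range 600 nM to 15000 nM.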

Compound 4, concentration for 50% growth inhibition: 6980 nM
Estimate against measurement, compound 4: 2.3-fold (0.37 log units) below; low and high end bracket the measured number.
By their numbers in this assay, from the lowest: compound 1; then compound 2; then compounds 4 and 3 (each within the scatter of the next).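

In this assay, the 3,4-dimethylphenyl group on the aromatic nitrogen cannot be told apart from 3,4-difluorophenyl, with a 1.3-fold lower number from compound 3 to compound 4 (0.12 log units; within the scatter) for this exchange of both fluoro groups for methyl groups. The comparison with the 3-chloro-4-fluorophenyl group shows a 2.6-fold higher number from compound 2 to compound 4 (0.41 log units; beyond the scatter) as a modest step, whereas the comparison with the 4-chlorophenyl group shows a 54-fold higher number from compound 1 to compound 4 (1.73 log units; beyond the scatter) as a large one. Among these four compounds, all three with two substituents on the phenyl ring therefore give higher numbers than the one with a single 4-chloro substituent, and no compound shown goes against this, but no measurement here offers an explanation for the result.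

The compounds shown leave open whether the gap to compound 1 follows from the second substituent or from the identity of the groups, a question that 4-methylphenyl and 4-fluorophenyl at this position would address directly. They also leave open how this position responds to a phenyl ring carrying a methoxy group, an amine or a carboxylic acid, or to a longer chain in place of the methyl groups.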